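The source may hold more compounds than are shown below. What is called first, only, known or untested is meant among the compounds shown, and "the series" means these compounds.

In an ADME assay (liver) for metabolic stability, with Liver microsome (Homo sapiens) as the target, read by LC-MS, using microsomes and NADPH, with a stated time of 5 min, at 37 degrees C (on this read-out lower numbers stand for slow clearance and higher numbers for fast clearance), compound 1 `CCn1c([C@@H](C)NS(=O)(=O)c2c(F)cc(F)cc2F)nc2ccc(C(F)(F)F)cc21` gives 19 mL.min-1.g-1 and compound 2 `CCn1c([C@@H](C)NS(=O)(=O)c2cn(C)nc2C)nc2ccc(C(F)(F)F)cc21` gives 28 mL.min-1.g-1, two values within the scatter of each other. Compound 3 `CCCn1cc(S(=O)(=O)N[C@H](C)c2nc3ccc(C(F)(F)F)cc3n2CC)c(C)n1` returns > 100 mL.min-1.g-1 as a limit of the assay and not a number. Compound 3 therefore stands at the limit of > 100 mL.min-1.g-1 in this assay, at which 1 of the 3 values shown sits, and has no exact value.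

The step to compound 4 `CCn1c([C@@H](C)NS(=O)(=O)c2cnc(C)n2C)nc2ccc(C(F)(F)F)cc21` is a group of 7 heavy atoms (5 carbon, 2 nitrogen; one five-membered aromatic ring with 2 hetero atoms) in place of a group of 9 heavy atoms (7 carbon, 2 nitrogen; one five-membered aromatic ring with 2 hetero atoms), on a sulfonyl sulfur, and 1,2-dimethyl-1H-imidazol-5-yl enters on the sulfonyl sulfur. The closest measured change is an at least 3.5-fold higher number from compound 2 to compound 3 (0.55 log units; beyond the scatter), with ethyl in place of hydrogen on a saturated chain carbon bound to an aromatic nitrogen. The wider comparison gives an at least 5.2-fold higher number from compound 1 to compound 3 (0.72 log units; beyond the scatter) in the same direction, while a 1.5-fold higher number from compound 1 to compound 2 (0.17 log units; within the scatter) shows a group exchange on the sulfonyl sulfur with no change beyond the scatter.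

Compound 4 carries 1,2-dimethyl-1H-imidazol-5-yl where compound 2 carries 1,3-dimethyl-1H-pyrazol-4-yl, so a fall beyond the scatter is expected, towards compound 2 at 28 mL.min-1.g-1 in this assay. The expected change is an at least 3.5-fold lower number from compound 3 to compound 4 (0.55 log units; beyond the scatter) in this estimate. For compound 4 the estimated value is 28 mL.min-1.g-1, with an expected range of 10 mL.min-1.g-1 to 70 mL.min-1.g-1.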

Compound 4, intrinsic clearance in microsomes: 58 mL.min-1.g-1
Beside the measured number, compound 4's estimate is 2.1-fold (0.32 log units) below it; the measured number falls inside the stated range.
By their numbers in this assay, from the lowest: compounds 1 and 2 (each within the scatter of the next); then compound 4. At a limit, above all of these: compound 3.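

On the sulfonyl sulfur, the choice between two dimethyl five-membered aromatic rings matters in this assay: 1,2-dimethyl-1H-imidazol-5-yl in place of 1,3-dimethyl-1H-pyrazol-4-yl gives a 2.1-fold higher number from compound 2 to compound 4 (0.32 log units; beyond the scatter). The earlier exchange of 2,4,6-trifluorophenyl for 1,3-dimethyl-1H-pyrazol-4-yl stayed within the scatter, whereas 1,2-dimethyl-1H-imidazol-5-yl in place of 2,4,6-trifluorophenyl gives a 3.1-fold higher number from compound 1 to compound 4 (0.48 log units; beyond the scatter). The remaining comparison reads an at least 1.7-fold lower number from compound 3 to compound 4 (0.23 log units; that floor lies within the scatter), which is a floor only, as its starting value is a limit of the assay and not a number: the limit of > 100 mL.min-1.g-1 in this assay, at which 1 of the 4 values shown sits.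

As far as these compounds go, what separates the two dimethyl rings in this read-out remains open. Also open, from the compounds shown here alone, is where an open-chain amine or a carboxylic acid on the sulfonyl sulfur would fall relative to these groups.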